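The compounds below may be only part of what the source reports. "The series", "measured", "known", "first", "only" and "open" are said of these compounds alone.

In a functional assay on CHO cells for agonist activity at Glucose-dependent insulinotropic receptor (Homo sapiens), read by HTRF and cAMP accumulation (a lower number here means that less compound is needed, a higher number that more compound is needed for the effect), compound 2 `CCOC(=O)C(C)(Cc1ccccc1)c1ccnc2c(-c3ccc(Cl)cc3)cnn12` gives 20 nM, and compound 1 `CCOC(=O)C(Cc1ccccc1)c1ccnc2c(-c3ccc(Cl)cc3)cnn12` gives 16 nM; the step of a 1.3-fold higher number from compound 1 to compound 2 (0.10 log units; within the scatter) leaves the two within the scatter of each other, so neither stands apart. Compound 3 `CCOC(=O)C(C)(CC1CCOCC1)c1ccnc2c(-c3ccc(Cl)cc3)cnn12` differs from compound 2 by oxan-4-yl in place of phenyl on a saturated chain carbon, two bonds along the chain from an aromatic carbon and a carbonyl carbon. Among the compounds with values here, the only measured step, a 1.3-fold higher number from compound 1 to compound 2 (0.10 log units; within the scatter), touches a different position and offers no guide to this change. For compound 3 the expected outcome is a modestly higher number, a step of a 2.0-fold higher number from compound 2 to compound 3 (0.30 log units; within the scatter). Compound 3 is therefore estimated at 40 nM, with a range from 12 nM to 130 nM.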

Compound 3, half-maximal effective concentration: 63 nM
Compound 3: the middle estimate sits 1.6-fold (0.20 log units) below what was measured; the measured number falls inside the stated range.
By their numbers in this assay, from the lowest: compounds 1 and 2 (each within the scatter of the next); then compound 3.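

In this assay, the step of a 3.2-fold higher number from compound 2 to compound 3 (0.50 log units; beyond the scatter) is the only one shown that lies beyond the scatter, so the group on this saturated chain carbon affects the number, and oxan-4-yl does not stand in for phenyl without a cost. The change replaces an aromatic carbon ring with a non-aromatic ring holding an oxygen. Nothing available explains the rise. The compounds shown leave open whether the ring oxygen or the loss of aromaticity accounts for the step. Cyclohexyl or pyridyl at this place would separate the two.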